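The source may report more compounds than this note shows. Statements on the series, on what has been measured and on what is new or still open speak of the compounds shown alone.

Measured so far in a physicochemical assay for lipophilicity, at pH 7.4; a lower number here means a more polar compound, a higher number a more lipophilic compound:

- compound 1 `Cc1[nH]c2ccccc2c(=O)c1Cc1ccccc1`: 1.93
- compound 2 `CCCCCCC/C=C/c1c(C)[nH]c2ccccc2c1=O`: 4.26
- compound 3 `Cc1[nH]c2ccc(F)cc2c(=O)c1Br`: 1.61

Of these three numbers, compound 1 holds the middle place. Compound 3 lies lower, and the gap is beyond the usual scatter of repeated measurements. Compound 2 lies much higher, also beyond the scatter.

Compound 4 `COc1ccc2[nH]c(C)c(Cc3ccccc3)c(=O)c2c1` keeps the core of compound 1 and changes it in one place: methoxy in place of hydrogen on an aromatic carbon. The new group sits on a six-membered aromatic ring of carbon only, part of a fused system of two rings.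

No two of the measured compounds differ in just one place, so the data contain no direct measure of what this swap does in this assay. Among the measured compounds shown here, the wide spread between compound 3 and compound 2 goes with much larger structural differences than this one, so it sets no size for this step. The expectation is therefore modest: a small rise at most, and probably nothing beyond the scatter. The estimated change is a number 0.12 log units higher from compound 1 to compound 4 (within the scatter). For compound 4 the estimated value is 2.05, with an expected range from 1.65 to 2.45.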

Compound 4, distribution coefficient: 2.53
The estimate for compound 4 lay 0.48 log units below the measured number; measured number above the stated range.
By their numbers in this assay, from the lowest: compound 3; then compound 1; then compound 4; then compound 2.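

Among the compounds shown here, this is the first direct reading of a single swap in this assay: methoxy in place of hydrogen on an aromatic carbon gives a number 0.60 log units higher from compound 1 to compound 4 (beyond the scatter). At this place on the six-membered aromatic ring of carbon only, meta to a fused ring and para to a fused ring, a small group of 2 heavy atoms is therefore enough to move the number by more than repeated measurements usually scatter. The step also has a clear direction, upward, which the earlier compounds could not show, since no two of them differed in just one place, and nothing measured here explains its size or direction.

This remains a single step, so it sets no rule for other groups or other places on the shared core. From the compounds shown here alone, whether an amine, a hydroxyl group or a carboxylic acid at this same carbon would raise or lower the number stays open, as does whether methoxy would give a similar step on another carbon of this ring.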